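Shifting the selenium group onto the ring of compound 1

The source may report more compounds than this note shows. Statements on the series, on what has been measured and on what is new or still open speak of the compounds shown alone.

Measured compounds:
compound 1, `COc1ccc(N(C)c2nc(C)nc3ccccc23)cc1C(=O)OCCC[Se]C#N`, 720 nM
compound 2, `Cc1nc(N(C)c2ccc([Se]C#N)c(F)c2)c2ccccc2n1`, 20 nM
compound 3, `CN(c1ccc([Se]C#N)cc1)c1nc(C2CC2)nc2ccccc12`, 62 nM

The three compounds share a core and were tested in a functional assay on HCT-116 cells (Homo sapiens) for inhibition, read by MTT assay, with a stated time of 48 h; a lower number here means a stronger inhibitor, a higher number a weaker inhibitor. Compound 1 has the highest number of the three with 720 nM. Its nearest neighbour is compound 3, which gives 62 nM, a gap beyond the scatter, and compound 2 gives 20 nM, the widest gap of all. In compounds 2 and 3 the selenium group sits directly on the aromatic ring; in compound 1 it lies at the end of an ester chain.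

Compound 4, `COc1ccc(N(C)c2nc(C)nc3ccccc23)cc1[Se]C`, has not yet been measured. It differs from compound 1 in one place: a group of 2 heavy atoms (1 carbon, 1 selenium; no ring) in place of a group of 9 heavy atoms (5 carbon, 1 nitrogen, 2 oxygen, 1 selenium; no ring), on an aromatic carbon. Going by the values given here, no step between measured compounds matches this change, so the account rests on what compounds 2 and 3 show and on the change itself. The step from compound 1 to compound 4 in this assay is expected to be modest, towards a lower number, a 1.8-fold lower number from compound 1 to compound 4 (0.26 log units; within the scatter), with little confidence that it clears the scatter. Compound 4 is therefore estimated at 400 nM, in a range from 100 nM to 2000 nM.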

Compound 4, half-maximal inhibitory concentration: 28 nM
Compound 4: the middle estimate sits 14-fold (1.15 log units) above what was measured, outside the stated range (below it).
By their numbers in this assay, from the lowest: compounds 2 and 4 (each within the scatter of the next); then compound 3; then compound 1.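

In this assay, the group of 2 heavy atoms (1 carbon, 1 selenium) in place of the group of 9 heavy atoms gives a 26-fold lower number from compound 1 to compound 4 (1.41 log units; beyond the scatter), a large step on an aromatic carbon ortho to a methoxy group. It shows that, at this position on the core of compound 1, neither the ester nor the nitrile is needed for a low number, since compound 4 carries selenium directly on the ring and has neither group. Nothing measured here bears on why the number falls so far.

This single step changes the ester, the chain and the nitrile together, so the contribution of each stays unresolved. Also open, from the compounds shown here alone, is what a nitrile on the selenium at this same carbon, a longer chain on the selenium, or an amine in its place would give.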